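A Halogen Swap on the Aryl Group of Compound 2

The source may hold more compounds than are shown below. What is called first, only, known or untested is meant among the compounds shown, and "the series" means these compounds.

Compound 2 `CCOC(=O)c1c(-c2c(Cl)c3ccccc3oc2=O)nn(-c2cccc(Cl)c2)c1C(=O)OCC` gives 38000 nM in a functional assay on A549 cells (Homo sapiens) for cytotoxicity, read by MTT assay, with a stated time of 48 h; a lower number here means a stronger inhibitor, a higher number a weaker inhibitor. Among the measured compounds shown here, it is one of only two compounds measured, and the other, compound 1 `CCOC(=O)c1c(-c2c(Cl)c3ccccc3oc2=O)nn(-c2cccc(C)c2)c1C(=O)OCC`, gives 36000 nM in this assay, so the two cannot be told apart by the numbers. For the measured compounds named here, the single measured step, a 1.1-fold higher number from compound 1 to compound 2 (0.02 log units; within the scatter), exchanges a methyl for a chloro on an aromatic carbon and shows that such a swap on the aryl ring left the read-out unchanged within the scatter. Compound 3 `CCOC(=O)c1c(-c2c(Cl)c3ccccc3oc2=O)nn(-c2ccc(Br)cc2)c1C(=O)OCC` differs from compound 2 by 4-bromophenyl in place of 3-chlorophenyl on an aromatic nitrogen. Going by the values given here, this is again a small change on the same aryl ring, and the one step that bears on it was flat, so a step of a 1.0-fold lower number from compound 2 to compound 3 (0.01 log units; within the scatter) is expected for compound 3, with no change beyond the scatter foreseen. Compound 3 is therefore estimated at 37000 nM, within a range from 15000 nM to 90000 nM.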

Compound 3, half-maximal inhibitory concentration: 30000 nM
Beside the measured number, compound 3's estimate is 1.2-fold (0.09 log units) above it, and the stated range covers the measured number.
By their numbers in this assay, from the lowest: compounds 3, 1 and 2 (each within the scatter of the next).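

The step of a 1.3-fold lower number from compound 2 to compound 3 (0.10 log units; within the scatter) and the step of a 1.2-fold lower number from compound 1 to compound 3 (0.08 log units; within the scatter) both stay within the scatter in this assay, so all three compounds read alike. Compound 1 and compound 2 differed only in the group on the same ring carbon, whereas the 4-bromophenyl group of compound 3 differs from both in its halogen and in where the ring carries it, and the read-out on this aromatic nitrogen still does not move beyond the scatter. Nothing available explains why these aryl groups read alike.

Each aryl ring shown carries only a methyl or a halogen, so it stays open whether an amine, a carboxylic acid or a longer chain on that ring would give a different number. On these data alone, the effect of replacing the ethoxycarbonyl groups shared by all three compounds also stays open.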